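Swapping 3,5-Dichlorophenyl for tert-Butoxy: an Expected Value

The compounds below may be only part of what the source reports. "The series", "measured", "known", "first", "only" and "open" are said of these compounds alone.

Three compounds have been measured in a functional assay for inhibition of sodium/hydrogen exchanger (Oryctolagus cuniculus); on this read-out higher numbers stand for weaker inhibition and lower numbers for stronger inhibition:
Compound 1 `Cc1c(C(=O)N=C(N)N)cc(S(C)(=O)=O)c(C)c1C` gives 55 nM.
Compound 2 `Cc1cc(Br)c(C(=O)N=C(N)N)cc1S(C)(=O)=O` gives 70 nM.
Compound 3 `Cc1cc(-c2cc(Cl)cc(Cl)c2)c(S(C)(=O)=O)cc1C(=O)N=C(N)N` gives 130 nM.

Compound 3 has the highest of these three numbers. Its gap to compound 2 lies within the scatter, so the two cannot be told apart, while compound 1 sits beyond the scatter with a lower number. Compound 4 `Cc1cc(OC(C)(C)C)c(S(C)(=O)=O)cc1C(=O)N=C(N)N` has not been measured yet. It differs from compound 3 in one place: tert-butoxy in place of 3,5-dichlorophenyl on an aromatic carbon. Among the measured compounds shown here, no step between two measured compounds covers this kind of change, so the expectation rests only on the spread of the three values. In this assay the expected step is a 1.6-fold lower number from compound 3 to compound 4 (0.21 log units; within the scatter), a modest move toward a lower number. This rests on compound 1, which gives 55 nM. Compound 4 is therefore estimated at 80 nM, with a range from 30 nM to 220 nM.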

Compound 4, half-maximal inhibitory concentration: 9.4 nM
For compound 4 the middle estimate is 8.5-fold (0.93 log units) above the measured one; the measured number lies below the stated range.
By their numbers in this assay, from the lowest: compound 4; then compounds 1, 2 and 3 (each within the scatter of the next, the first and the last beyond it).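

In this assay, putting tert-butoxy in place of 3,5-dichlorophenyl gives a 14-fold lower number from compound 3 to compound 4 (1.14 log units; beyond the scatter) and so shows that this aromatic carbon, ortho to a methylsulfonyl group, can strongly shift inhibition. The swap removes a ring and brings in an oxygen at once, so this single step cannot show which of these changes matters. Nothing measured here explains the size of the step. On these data alone, whether the oxygen is needed remains open, and a tert-butyl or methoxy group at this place would help to separate the two changes.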